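The compounds below may be only part of what the source reports. "The series", "measured", "known", "first", "only" and "open" are said of these compounds alone.

Measured in a functional assay on NIH3T3 cells (Mus musculus) for inhibition, read by MTT assay, with a stated time of 72 h; a higher number here means a weaker inhibitor, a lower number a stronger inhibitor:
- Compound 1 `C=C1CC[C@H]2[C@@](C)(CC[C@@H](OC(C)=O)[C@@]2(C)C(=O)OC)[C@@H]1CCC1=CCOC1=O`: 80600 nM
- Compound 2 `C=C1CC[C@H]2[C@@](C)(CC[C@@H](O)[C@@]2(C)C(=O)OC)[C@@H]1CCC1=CCOC1=O`: 60600 nM

Only these two numbers exist, and they do not separate: a 1.3-fold lower number from compound 1 to compound 2 (0.12 log units; within the scatter). Compound 3 `C=C1CC[C@H]2[C@@](C)(CC[C@@H](OC(C)=O)[C@@]2(C)C(=O)OC)[C@@H]1/C=C/C1=CCOC1=O` keeps the core of compound 1 and exchanges one group: a group of 8 heavy atoms (6 carbon, 2 oxygen; one five-membered non-aromatic ring with 1 hetero atom) in place of a group of 8 heavy atoms (6 carbon, 2 oxygen; one five-membered non-aromatic ring with 1 hetero atom), on a saturated ring carbon. The entering group has 3 double bonds outside aromatic rings, and the leaving group has 2. Among the measured compounds shown here, the one measured step placed hydrogen in place of acetyl on an oxygen, a different change, so it offers only a weak guide. No step beyond the scatter is expected in this assay. The expected value for compound 3 is 70000 nM, within an estimated range of 30000 nM to 160000 nM. The estimated step is a 1.2-fold lower number from compound 1 to compound 3 (0.06 log units; within the scatter).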

Compound 3, half-maximal inhibitory concentration: 32300 nM
The estimate for compound 3 lay 2.2-fold (0.34 log units) above the measured number; low and high end bracket the measured number.
By their numbers in this assay, from the lowest: compounds 3, 2 and 1 (each within the scatter of the next, the first and the last beyond it).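

Among the compounds shown here, exchanging the group on the saturated ring carbon gives a 2.5-fold lower number from compound 1 to compound 3 (0.40 log units; beyond the scatter) in this assay and is the first step to pass the scatter, though only modestly. The two groups have the same count of 8 heavy atoms, and the entering group has 3 double bonds outside aromatic rings where the leaving group has 2, so this position responds to a small change. Nothing available explains the step.

Still open, going by these compounds, is how a longer chain or a carboxylic acid at this position would compare. Also open, on these data alone, is whether hydrogen in place of acetyl on the oxygen would matter alongside the entering group.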